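Same ring swap on two closely related cores

A few compounds are considered here, and "the series" means these few. Any claim that something is new, unique, unknown or untested is made for them only; others in the source may bear on it.

Compound 1 `COc1cc(Nc2nc3ccccc3nc2S(=O)(=O)c2ccc(C)cc2)cc(OC)c1` in a functional assay on HCT-116 cells (Homo sapiens) for cytotoxicity, read by MTT assay, with a stated time of 72 h (a lower number here means a stronger inhibitor, a higher number a weaker inhibitor), gives > 50000 nM, which is a limit of the assay rather than a number.
Compound 2 `Cc1ccc(S(=O)(=O)c2nc3ccccc3nc2Nc2ccc(N)cc2)cc1` in this assay gives 11500 nM.
Compound 3 `COc1ccc(S(=O)(=O)c2nc3ccccc3nc2Nc2cc(OC)cc(OC)c2)cc1` in this assay gives 13400 nM.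

Compound 1 and compound 3 differ only in methoxy in place of methyl on an aromatic carbon. That change brings an at least 3.7-fold lower number from compound 1 to compound 3 (0.57 log units; beyond the scatter). Since compound 1 sits at the limit of > 50000 nM in this assay, at which 1 of the 3 values shown sits, the true size of this step is not known. Compound 2 differs from compound 1 in 4-aminophenyl in place of 3,5-dimethoxyphenyl on a nitrogen on an aromatic ring, and that change brings an at least 4.3-fold lower number from compound 1 to compound 2 (0.63 log units; beyond the scatter), again measured from a limit. Compound 2 and compound 3 lie within the usual scatter of each other.

Compound 4 `COc1ccc(S(=O)(=O)c2nc3ccccc3nc2Nc2ccc(N)cc2)cc1` has not yet been measured. It differs from compound 3 in 4-aminophenyl in place of 3,5-dimethoxyphenyl on a nitrogen on an aromatic ring, the same change, at the same place, as from compound 1 to compound 2. Because both steps from compound 1 start at the limit of > 50000 nM in this assay, at which 1 of the 3 values shown sits, only a floor for each is known. The step from compound 3 to compound 4 is expected to be a 2.2-fold lower number from compound 3 to compound 4 (0.35 log units; beyond the scatter), a cautious guess that rests on compound 1 giving > 50000 nM and compound 2 giving 11500 nM. Compound 4 is estimated at 6000 nM, likely between 2000 nM and 20000 nM.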

Compound 4, half-maximal inhibitory concentration: 6300 nM
Compound 4: middle estimate off by 1.1-fold (0.02 log units), on the low side; the measured number falls inside the stated range.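

Putting 4-aminophenyl in place of 3,5-dimethoxyphenyl on the nitrogen brings a 2.1-fold lower number from compound 3 to compound 4 (0.33 log units; beyond the scatter), the same direction as the step seen earlier on the core carrying methyl: the same change on two cores in this assay, an at least 4.3-fold lower number (0.63 log units; beyond the scatter) from compound 1 to compound 2 and a 2.1-fold lower number (0.33 log units; beyond the scatter) from compound 3 to compound 4; the limit leaves it open whether they differ

The other change, methoxy in place of methyl on an aromatic carbon, brings a 1.8-fold lower number from compound 2 to compound 4 (0.26 log units; within the scatter), and this step lies within the usual scatter, so on this pair it cannot be told apart from no change: the same change on two cores in this assay, an at least 3.7-fold lower number (0.57 log units; beyond the scatter) from compound 1 to compound 3 and a 1.8-fold lower number (0.26 log units; within the scatter) from compound 2 to compound 4; the limit leaves it open whether they differ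

The direction of the ring swap thus carried over to the second core, yet whether its size did stays unknown, as compound 1 sits at a limit and not at a number: the limit of > 50000 nM in this assay, at which 1 of the 4 values shown sits.

All of this rests on two cores and on this assay alone, so it is no general rule for the series. Still open, on these data alone, is how the swap behaves with chlorine or trifluoromethyl in place of methyl or methoxy, and what a 4-hydroxyphenyl or a carboxylic acid on that ring would do.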